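Phenyl for Dichlorophenyl: Expected Cost in Receptor Binding

The source may hold more compounds than are shown below. What is called first, only, known or untested is meant among the compounds shown, and "the series" means these compounds.

Compound 3 `CCCc1cc(N)c2cc(NC(=O)/C=C/c3ccc(Cl)cc3Cl)ccc2n1` gives 6.6 nM in an assay on isolated protein for displacement of a labelled ligand from melanin-concentrating hormone receptor 1 (Homo sapiens) (on this read-out lower numbers stand for stronger inhibition and higher numbers for weaker inhibition), the higher of the two numbers in hand; the nearest is compound 1 `CCCc1cc(NC)c2cc(NC(=O)/C=C/c3ccc(C(F)(F)F)cc3)ccc2n1`, which gives 1.5 nM, a gap beyond the scatter. Compound 2 `CCCc1cc(N2CCCCC2)c2cc(NC(=O)/C=C/c3ccc(C(F)(F)F)cc3)ccc2n1` gives only a limit of the assay, > 4000 nM. Among the measured compounds shown here, the one measured step, an at least 2600-fold higher number from compound 1 to compound 2 (3.42 log units; beyond the scatter), concerns the amino group on the shared core and is large. Compound 4 `CCCc1cc(N)c2cc(NC(=O)/C=C/c3ccccc3)ccc2n1` differs from compound 3 elsewhere: phenyl in place of 2,4-dichlorophenyl on a double-bonded chain carbon bound to a double-bonded chain carbon. For the measured compounds named here, no measured step touches this aryl group, so the size of the coming change cannot be read from the data; a moderate weakening is nevertheless expected, a 4.5-fold higher number from compound 3 to compound 4 (0.66 log units; beyond the scatter). Compound 4 is therefore estimated at 30 nM, within 8 nM to 150 nM.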

Compound 4, half-maximal inhibitory concentration: 1000 nM
Estimate against measurement, compound 4: 33-fold (1.52 log units) below; measured number outside the range, above it.
By their numbers in this assay, from the lowest: compound 1; then compound 3; then compound 4. At a limit, above all of these: compound 2.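

The aryl group on the double-bonded chain carbon, untouched by any earlier step, proves to be a sensitive place: with phenyl in place of 2,4-dichlorophenyl there is a 150-fold higher number from compound 3 to compound 4 (2.18 log units; beyond the scatter). The earlier step showed a large change at the amino group on the shared core, and this one shows that a change at the other end of the molecule can also be large. The compounds shown leave open whether a single chlorine would be enough, or whether a methyl or methoxy group could stand in its place. Nothing measured here says why removing the two chlorines matters so much.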